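A few compounds are considered here, and "the series" means these few. Any claim that something is new, unique, unknown or untested is made for them only; others in the source may bear on it.

For the measured compounds named here, in a functional assay on MCF7 cells (Homo sapiens) for inhibition (a lower number here means a stronger inhibitor, a higher number a weaker inhibitor), compound 1 `CCCCCCCCCCCCCCCCCCOC[C@H](COP(=O)(O)O[C@@H]1[C@H](O)[C@@H](CO)[C@@H](O)[C@H](O)[C@@H]1O)OC` gives 2000 nM, the lower of the two numbers so far, and compound 2 `CCCCCCCCCCCCCCCCCCOC[C@H](COC(=O)O[C@@H]1[C@H](O)[C@@H](CO)[C@@H](O)[C@H](O)[C@@H]1O)OC` gives 12500 nM. Compound 3 `CCCCCCCCCCCCCCCCCCOC[C@H](COP(=O)(O)O[C@@H]1[C@H](O)[C@H](CO)[C@@H](O)[C@H](O)[C@@H]1O)OC` differs from compound 1 at one place, the two compounds have the same atoms and bonds; at least one stereo element is drawn with a configuration in one of them and without one in the other: 1 of 8 stereo elements differ; a stereocentre at a saturated ring carbon is drawn S in compound 1 and R in compound 3: a stereocentre at a saturated ring carbon is drawn S in compound 1 and R in compound 3. Going by the values given here, no measured pair isolates a change of this kind, so the expectation is loosely held. The estimated step of a 1.8-fold higher number from compound 1 to compound 3 (0.24 log units; within the scatter) is a small rise in the number, towards weaker inhibition, and may not exceed the scatter. For compound 3 the expected value is 3500 nM, with an estimated range of 1200 nM to 12000 nM.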

Compound 3, half-maximal inhibitory concentration: 5000 nM
Estimate against measurement, compound 3: 1.4-fold (0.15 log units) below; low and high end bracket the measured number.
By their numbers in this assay, from the lowest: compound 1; then compound 3; then compound 2.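

For the compounds shown here, this is the first change read on its own: in this assay, a single stereocentre at a saturated ring carbon, drawn S or R, gives a 2.5-fold higher number from compound 1 to compound 3 (0.40 log units; beyond the scatter). Configuration at this place alone therefore moves the number, with atoms and bonds unchanged. One caution attaches to this reading: the fact that one of compounds 1 and 3 is drawn with a defined configuration and the other without, at the place where they differ.

On these data alone, it remains open whether the other stereo elements of the shared core matter as much, and whether the R configuration acts the same way with the carbonate link of compound 2. As far as these compounds go, how an amine in place of a ring hydroxyl would fare with either configuration also stays open.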